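Triazole-linked analogues: sugar to diol swap

A few compounds are considered here, and "the series" means these few. Any claim that something is new, unique, unknown or untested is made for them only; others in the source may bear on it.

Compound 1 `CN1CCN(CCCCCCn2c3c(c4ccccc42)C(=O)c2c[n+]([O-])c4ccccc4c2C3=O)CC1`: 400 nM in a functional assay on MCF7 cells (Homo sapiens) for cytotoxicity, read by MTT assay, with a stated time of 72 h; on this read-out lower numbers stand for stronger inhibition and higher numbers for weaker inhibition
Compound 2 `CN1CCN(CCCCCn2c3c(c4ccccc42)C(=O)c2c[n+]([O-])c4ccccc4c2C3=O)CC1`: 1260 nM
Compound 3 `O=C1c2c[n+]([O-])c3ccccc3c2C(=O)c2c1c1ccccc1n2Cc1cn([C@H]2C[C@H](O)[C@@H](CO)O2)nn1`: 530 nM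

Compound 3 stands second highest of the three numbers: its gap to compound 1 lies within the scatter, its gap to compound 2 beyond it. Compound 4 `O=C1c2c[n+]([O-])c3ccccc3c2C(=O)c2c1c1ccccc1n2Cc1cn(C[C@@H](O)CO)nn1` differs from compound 3 by 2,3-dihydroxypropyl in place of 4-hydroxy-5-(hydroxymethyl)oxolan-2-yl on an aromatic nitrogen. For the measured compounds named here, the only measured step, a 3.2-fold higher number from compound 1 to compound 2 (0.50 log units; beyond the scatter), concerns the saturated chain on the core of compound 1, not the group on the aromatic nitrogen of the five-membered aromatic ring with 3 nitrogen, so no measured step bears directly on this swap. With both groups carrying 2 hydrogen-bond donors, a step of modest size at most is expected in this assay, direction uncertain. Compound 4 is estimated at 750 nM (range 300 nM to 2000 nM), a step of a 1.4-fold higher number from compound 3 to compound 4 (0.15 log units; within the scatter) being expected.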

Compound 4, half-maximal inhibitory concentration: 600 nM
Compound 4: the middle estimate sits 1.3-fold (0.10 log units) above what was measured; low and high end bracket the measured number.
By their numbers in this assay, from the lowest: compounds 1, 3 and 4 (each within the scatter of the next); then compound 2.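

In this assay, 2,3-dihydroxypropyl in place of 4-hydroxy-5-(hydroxymethyl)oxolan-2-yl on the aromatic nitrogen gives a 1.1-fold higher number from compound 3 to compound 4 (0.05 log units; within the scatter), so this position accepts the loss of the five-membered non-aromatic ring without a step beyond the scatter. Against the chains ending in 4-methylpiperazin-1-yl, the 1-(2,3-dihydroxypropyl)-1H-1,2,3-triazol-4-yl group gives a 2.1-fold lower number from compound 2 to compound 4 (0.32 log units; beyond the scatter) and a 1.5-fold higher number from compound 1 to compound 4 (0.18 log units; within the scatter). No evidence on why these numbers fall as they do is at hand.

From the compounds shown here alone, whether an amine or a carboxylic acid on this aromatic nitrogen would hold the number stays open. So does the effect of a longer chain carrying a single hydroxyl.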